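The source may report more compounds than this note shows. Statements on the series, on what has been measured and on what is new or still open speak of the compounds shown alone.

Compound 1 `CN(c1cccc2c1CN(c1nc(Nc3ccc(C(F)(F)F)cc3)ncc1C(F)(F)F)C2)S(C)(=O)=O` — > 30000 nM
Compound 2 `Cc1ccc(Nc2ncc(C(F)(F)F)c(N3Cc4cccc(N(C)S(C)(=O)=O)c4C3)n2)c(Cl)c1` — > 30000 nM
Compound 3 `COc1cc(Nc2ncc(C(F)(F)F)c(N3Cc4cccc(N(C)S(C)(=O)=O)c4C3)n2)cc(C(F)(F)F)c1` — > 30000 nM

In a functional assay on A549 cells (Homo sapiens) for antiproliferative activity, read by spectrophotometry, with a stated time of 2 days (on this read-out lower numbers stand for stronger inhibition of growth and higher numbers for weaker inhibition of growth), compound 1 gives only > 30000 nM, which is a limit of the assay and not a number. Compound 2 likewise stands at a limit in this assay. Compound 3 also stands at a limit there. All three sit at the limit of > 30000 nM in this assay, at which 3 of the 3 values shown sit, so the steps a step that the two limits leave unreadable from compound 1 to compound 2, a step that the two limits leave unreadable from compound 1 to compound 3 and a step that the two limits leave unreadable from compound 2 to compound 3 cannot be read.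

Compound 4 `Cc1ccc(Nc2ncc(C(F)(F)F)c(N3Cc4cccc(N(C)S(C)(=O)=O)c4C3)n2)c(C)c1` differs from compound 1 by 2,4-dimethylphenyl in place of 4-(trifluoromethyl)phenyl on a nitrogen on an aromatic ring. The measured steps that bear on this change each swap the same group for another substituted phenyl, and none of them is readable. The step of a number no higher from compound 1 to compound 4 (the limit leaves the size open) is therefore expected to stay unreadable as well. Compound 4 is estimated at 30000 nM, within 8000 nM to 100000 nM.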

Compound 4, concentration for 50% growth inhibition: 20700 nM
Estimate against measurement, compound 4: 1.4-fold (0.16 log units) above; low and high end bracket the measured number.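

In this assay, for the compounds shown here, compound 4 gives 20700 nM, the only value shown at this position that is a number and not a limit. The 2,4-dimethylphenyl group therefore brings the series onto the readable scale, whereas the other three compounds stop at a limit: the limit of > 30000 nM in this assay, at which 3 of the 4 values shown sit. On these data alone, the steps are an at least 1.4-fold lower number from compound 1 to compound 4 (0.16 log units; that floor lies within the scatter), an at least 1.4-fold lower number from compound 3 to compound 4 (0.16 log units; that floor lies within the scatter) and, with methyl in place of chloro, an at least 1.4-fold lower number from compound 2 to compound 4 (0.16 log units; that floor lies within the scatter); each is only a floor, and its true size stays open.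

The compounds shown leave open whether a single methyl on the phenyl ring would suffice. They also leave open how an amine or a carboxylic acid on that ring would read.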